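Swapping a Methoxyphenyl for a Difluorophenyl on the Ketone

The source may report more compounds than this note shows. Statements on the series, on what has been measured and on what is new or still open speak of the compounds shown alone.

Compound 1 `COc1ccc(-c2cc(/C=C/C(=O)c3ccc(OC)c(OC)c3)[nH]n2)cc1`: 95%
Compound 2 `COc1ccc(-c2cc(/C=C/C(=O)c3ccc(N)cc3)[nH]n2)cc1`: 103%
Compound 3 `COc1ccc(C(=O)/C=C/c2cc(-c3cc(OC)c(OC)c(OC)c3)n[nH]2)cc1`: 95%

In a functional assay on MDA-MB-435 cells (Homo sapiens) for cytotoxicity, read by sulforhodamine B assay, with a stated time of 48 h, tested at 0.1 uM (on this read-out higher numbers stand for a weaker effect at the one concentration tested and lower numbers for a stronger effect), compound 1 gives 95%, compound 2 gives 103% and compound 3 gives 95%. Compound 3 stands level with compound 1 at the digits shown and together they are the lowest of the three numbers, yet all three values lie within the scatter of one another, so no compound can be called stronger or weaker than another.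

Compound 4 `COc1cc(-c2cc(/C=C/C(=O)c3ccc(F)c(F)c3)[nH]n2)cc(OC)c1OC` differs from compound 3 in one place: 3,4-difluorophenyl in place of 4-methoxyphenyl on a carbonyl carbon. Among the compounds with values here, no step between two measured compounds is known, and none of the measured compounds shows what this change does. In this assay the expected step is a number 2 percentage points higher from compound 3 to compound 4 (within the scatter), none beyond the scatter. Compound 4 is estimated at 97%, between 85% and 108%.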

Compound 4, a percentage reported as activity, at one concentration (the size of the read-out at that concentration, not a potency): 90%
Compound 4: middle estimate off by 7 percentage points, on the high side, and the stated range covers the measured number.
By their numbers in this assay, from the lowest: compounds 4, 1, 3 and 2 (each within the scatter of the next, the first and the last beyond it).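

In this assay, within the data shown here, 3,4-difluorophenyl in place of 4-methoxyphenyl on a carbonyl carbon gives a number 5 percentage points lower from compound 3 to compound 4 (within the scatter), the first comparison here between compounds that differ in one place. At this single concentration, the swap therefore does not separate the two compounds. Nothing available explains the step or links it to any property of either group. As far as these compounds go, it remains open whether a phenyl ring carrying a carboxylic acid, or a cyclohexyl group, in this place would give a number beyond the scatter.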